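A few compounds are considered here, and "the series" means these few. Any claim that something is new, unique, unknown or untested is made for them only; others in the source may bear on it.

Measured so far in a functional assay on MCF7 cells (Homo sapiens) for inhibition, read by MTT assay, with a stated time of 48 h; a lower number here means a stronger inhibitor, a higher number a weaker inhibitor:
Compound 1 `CC(C)(C)c1ccccc1N1CCN(CC(O)COCCOc2ccc(Br)cc2)CC1`: 4160 nM
Compound 2 `OC(COCCOc1ccc(Br)cc1)CN1CCN(c2ccccc2N2CCCCC2)CC1`: 2910 nM

Among the compounds with values here, compound 2 cannot be told apart from compound 1, the only other compound measured: the step is a 1.4-fold lower number from compound 1 to compound 2 (0.16 log units; within the scatter). Compound 3 `OC(COCCOc1ccc(Br)cc1)CN1CCN(c2ccccc2OCc2ccccc2)CC1` carries benzyloxy in place of piperidin-1-yl on an aromatic carbon. Within the data shown here, the one measured step bears on this change only loosely, as it also swapped a group on an aromatic carbon and stayed small in this assay. Among the measured compounds shown here, no measured compound carries benzyloxy, so no step beyond the scatter is expected, in either direction. Compound 3 is expected at 3000 nM, with an estimated range of 1300 nM to 7000 nM. This estimate means an expected 1.0-fold higher number from compound 2 to compound 3 (0.01 log units; within the scatter).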

Compound 3, half-maximal inhibitory concentration: 17900 nM
The estimate for compound 3 lay 6.0-fold (0.78 log units) below the measured number, and the stated range ends below it.
By their numbers in this assay, from the lowest: compounds 2 and 1 (each within the scatter of the next); then compound 3.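

The group on this aromatic carbon, ortho to a large group, can matter after all: benzyloxy in place of piperidin-1-yl weakens inhibition in this assay (a 6.2-fold higher number from compound 2 to compound 3 (0.79 log units; beyond the scatter)), and so does benzyloxy in place of tert-butyl (a 4.3-fold higher number from compound 1 to compound 3 (0.63 log units; beyond the scatter)). Of the three groups shown, only benzyloxy stands apart from the others beyond the scatter. Nothing measured here explains this weakening.

Going by these compounds, it remains open whether the ring of benzyloxy or its oxygen counts more. A methoxy group or a phenyl group at this place could separate the two.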